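Shortening the chain on the carbonyl: compound 4 expected near compound 3

A few compounds are considered here, and "the series" means these few. Any claim that something is new, unique, unknown or untested is made for them only; others in the source may bear on it.

compound 1, `CC1=C(C(=O)NC(C)C)C(c2ccco2)NC(=O)N1`: 4%
compound 2, `CCSC(=O)C1=C(C)NC(=O)NC1c1ccco1`: 14%
compound 3, `CCC(CC)OC(=O)C1=C(C)NC(=O)NC1c1ccco1`: 1%

All three numbers come from an assay on membranes from HeLa cells for displacement of a labelled ligand from adenosine receptor A3 (Homo sapiens), read by scintillation counting, with a stated time of 180 min, tested at 1 uM; on this read-out lower numbers stand for less inhibition and higher numbers for more inhibition at the one concentration tested (going by the name of the read-out). Compound 3 gives the lowest of the three; its gap to compound 1 is within the scatter, a number 3 percentage points lower from compound 1 to compound 3 (within the scatter), while its gap to compound 2 is beyond it, a number 13 percentage points lower from compound 2 to compound 3 (beyond the scatter). Compound 1 and compound 2 sit within the scatter of each other, a number 10 percentage points higher from compound 1 to compound 2 (within the scatter).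

Compound 4, `CCC(C)OC(=O)C1=C(C)NC(=O)NC1c1ccco1`, differs from compound 3 by hydrogen in place of methyl on a saturated chain carbon, two bonds along the chain from an oxygen next to a carbonyl group. Among the compounds with values here, no measured step removes a single methyl from this chain; the steps that bear on it are the exchanges of the whole group on the carbonyl carbon, a number 3 percentage points lower from compound 1 to compound 3 (within the scatter) and a number 13 percentage points lower from compound 2 to compound 3 (beyond the scatter), and the larger of these replaces ethylsulfanyl by (pentan-3-yl)oxy, a different kind of change from trimming one carbon. Removing a methyl from a chain that already gives the lowest number is expected to move the read-out little: the expected step is a number 3 percentage points higher from compound 3 to compound 4 (within the scatter), not beyond the scatter. Compound 4 is therefore estimated at 4%, between -5% and 14%.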

Compound 4, a percentage reported as inhibition, at one concentration (the size of the read-out at that concentration, not a potency): 3%
Compound 4: the middle estimate sits 1 percentage points above what was measured, and the stated range covers the measured number.
By their numbers in this assay, from the lowest: compounds 3, 4, 1 and 2 (each within the scatter of the next, the first and the last beyond it).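

In this assay, within the data shown here, the trim from (pentan-3-yl)oxy to sec-butoxy gives the first reading of a single methyl on this saturated chain carbon, and the change stays within the scatter (a number 2 percentage points higher from compound 3 to compound 4 (within the scatter)). Sec-butoxy also lies within the scatter of isopropylamino on the carbonyl carbon (a number 1 percentage points lower from compound 1 to compound 4 (within the scatter)) but beyond it from ethylsulfanyl (a number 11 percentage points lower from compound 2 to compound 4 (beyond the scatter)), so the gap to ethylsulfanyl now holds for two different alkoxy groups, compound 3 and compound 4. No supporting measurement is available to explain these numbers.

As far as these compounds go, an ethoxy group on the carbonyl carbon would pair directly with the ethylsulfanyl of compound 2, and that comparison remains open. Also open, from the compounds shown here alone, is whether a methoxy group or a longer chain would shift the number beyond the scatter.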